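The compounds below may be only part of what the source reports. "The series", "measured", "known", "first", "only" and "open" are said of these compounds alone.

In a functional assay on HepG2 cells (Homo sapiens) for antiproliferative activity, read by CCK-8 assay, with a stated time of 72 h (a higher number here means a weaker inhibitor, a lower number a stronger inhibitor), compound 1 (`Nc1ccccc1NC(=O)c1ccc(Cn2cnc3c(Nc4ccccc4)nc(Cl)nc32)cc1`) gives 4180 nM. Two relatives sit close by: compound 2 (`CC(C)n1cnc2c(NCc3ccc(C(=O)Nc4ccccc4N)cc3)nc(Cl)nc21`) gives 3320 nM, and compound 3 (`Nc1ccccc1NC(=O)c1ccc(COCNc2nc(Nc3ccccc3)c3ncn(C4CCCC4)c3n2)cc1`) gives 6020 nM. Both lie within the usual scatter of compound 1, so these numbers set no order between compound 1 and either neighbour. Compound 4 (`CN1CCN(c2nc(Cl)nc3c2ncn3Cc2ccc(C(=O)Nc3ccccc3N)cc2)CC1`) has not been measured yet. It keeps the rest of compound 1 and makes one change: 4-methylpiperazin-1-yl in place of anilino on an aromatic carbon. Going by the values given here, no measured pair isolates this kind of swap, so the data give no direct guide to its size. Compound 2, at 3320 nM, differs from compound 1 in more than one place and still lies within the scatter of it, so only a modest step in this assay is expected, most likely none beyond the scatter, and if anything towards a higher number. The expected change is a 1.1-fold higher number from compound 1 to compound 4 (0.03 log units; within the scatter). For compound 4 the estimated half-maximal inhibitory concentration is 4500 nM, with an expected range from 1500 nM to 13000 nM.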

Compound 4, half-maximal inhibitory concentration: 2010 nM
Compound 4: middle estimate off by 2.2-fold (0.35 log units), on the high side, within the range that was stated.
By their numbers in this assay, from the lowest: compounds 4, 2, 1 and 3 (each within the scatter of the next, the first and the last beyond it).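

In this assay, putting 4-methylpiperazin-1-yl in place of anilino gives a 2.1-fold lower number from compound 1 to compound 4 (0.32 log units; beyond the scatter), a modest step and the first at this position that can be read beyond the scatter. Compound 4 has neither the aromatic ring nor the hydrogen-bond donor of the anilino group, yet its number is lower, so at this position neither feature is needed for activity at this level in cells. Nothing here explains the step, and no measurement bears on its cause.

This single step cannot show whether the lower number follows from the non-aromatic ring, its second nitrogen or its methyl group; morpholin-4-yl, piperidin-1-yl and piperazin-1-yl would separate these. Going by these compounds, whether the step would hold with a methoxy group in place of the chloro group also stays open.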